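A Ring Swap Starting From an Assay Limit

The source may report more compounds than this note shows. Statements on the series, on what has been measured and on what is new or still open speak of the compounds shown alone.

In a functional assay on K562 cells (Homo sapiens) for antiproliferative activity, with a stated time of 72 h (a higher number here means a weaker inhibitor, a lower number a stronger inhibitor), compound 1 `OC[C@H]1O[C@@H](n2cnc3c(NCc4cccc(F)c4)ncnc32)[C@H](O)[C@@H]1O` gives 7600 nM. Compound 2 `Cc1ccc(CNc2ncnc3c2ncn3[C@@H]2O[C@H](CO)[C@@H](O)[C@H]2O)cc1` gives > 166000 nM in this assay, and this is a limit of the assay, not a number. Compound 3 `OC[C@H]1O[C@@H](n2cnc3c(NCc4ccc(Cl)cc4Cl)ncnc32)[C@H](O)[C@@H]1O` carries 2,4-dichlorophenyl in place of the 4-methylphenyl of compound 2, on a saturated chain carbon bound to a nitrogen on an aromatic ring (2,4-dichlorophenyl in place of 4-methylphenyl on a saturated chain carbon bound to a nitrogen on an aromatic ring). For the measured compounds named here, only one measured step bears on this change, and it falls at the same place: an at least 21-fold higher number from compound 1 to compound 2 (1.33 log units; beyond the scatter). That large step shows that the group here can move the result strongly, so a single step gives little guide to the new group. A shift towards stronger inhibition is expected, because compound 2 has > 166000 nM as its limit. The expected step in this assay is an at least 6.6-fold lower number from compound 2 to compound 3 (0.82 log units; beyond the scatter). For compound 3 the estimated value is 25000 nM, with an expected range of 4000 nM to 150000 nM.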

Compound 3, half-maximal inhibitory concentration: 106000 nM
Compound 3: middle estimate off by 4.2-fold (0.63 log units), on the low side; the range from low to high includes it.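

Compound 3 gives a measured value at this position where compound 2 gave only a limit, and it still falls well short of compound 1, with a 14-fold higher number from compound 1 to compound 3 (1.14 log units; beyond the scatter). Both groups tried in place of 3-fluorophenyl therefore give much weaker results in this assay, so the loss is not tied to 4-methylphenyl alone. The change to 2,4-dichlorophenyl yields an at least 1.5-fold lower number from compound 2 to compound 3 (0.19 log units; that floor lies within the scatter), which shows no real gain, and the comparison gives only a floor because compound 2 stands at a limit of the assay: the limit of > 166000 nM in this assay, at which 1 of the 3 values shown sits.

On these data alone, the true size of the change from 4-methylphenyl to 2,4-dichlorophenyl stays unknown. As far as these compounds go, it also stays open whether compound 1 owes its edge to the fluorine itself, a question that an unsubstituted phenyl at the same place could help to settle.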